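Changing the Group on the Ring Nitrogen

The source may hold more compounds than are shown below. What is called first, only, known or untested is meant among the compounds shown, and "the series" means these compounds.

Of the compounds shown here, three that share one core have been measured so far: compound 1 `Oc1cc(C(F)(F)F)ccc1-c1nc(-c2ccccc2O)n(-c2ccc(Cl)cc2)n1`, compound 2 `Oc1cc(C(F)(F)F)ccc1-c1nc(-c2ccccc2O)n(-c2ccc(I)cc2)n1` and compound 3 `Oc1cc(C(F)(F)F)ccc1-c1nc(-c2ccccc2O)n(-c2ccc(OC(F)(F)F)cc2)n1`. In a functional assay on PC-12 cells (Rattus norvegicus) for cytotoxicity, read by MTT assay, with stated times of 2 h and 24 h, tested at 10 uM (on this read-out higher numbers stand for a stronger effect at the one concentration tested and lower numbers for a weaker effect), compound 1 gives 96.1%, compound 2 gives 105% and compound 3 gives 92.5%. Compound 3 thus stands lowest of the three numbers, but its distance to compound 1 lies within the scatter, and only its distance to compound 2 lies beyond it. The three differ in a single group sitting on an aromatic carbon of the ring attached to the aromatic nitrogen of the shared core: a number 8.9 percentage points higher from compound 1 to compound 2 (within the scatter), a number 3.6 percentage points lower from compound 1 to compound 3 (within the scatter), a number 12.5 percentage points lower from compound 2 to compound 3 (beyond the scatter).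

Compound 4 `Oc1cc(C(F)(F)F)ccc1-c1nc(-c2ccccc2O)n(-c2ccccc2C(F)(F)F)n1` alters the same region: 2-(trifluoromethyl)phenyl in place of 4-(trifluoromethoxy)phenyl on an aromatic nitrogen. All three measured steps bear on this change, since each also exchanges what sits on that ring, and none of them moved the read-out by more than a modest amount. Accordingly, no step beyond the scatter is expected in this assay from this exchange; the expected step is a number 2.5 percentage points higher from compound 3 to compound 4 (within the scatter). Compound 4 is therefore estimated at 95%, with a range from 80% to 110%.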

Compound 4, a percentage reported as activity, at one concentration (the size of the read-out at that concentration, not a potency): 92.2%
Beside the measured number, compound 4's estimate is 2.8 percentage points above it; the range from low to high includes it.
By their numbers in this assay, from the lowest: compounds 4, 3, 1 and 2 (each within the scatter of the next, the first and the last beyond it).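

All the earlier groups on the ring attached to the aromatic nitrogen were named at its 4 position (4-chlorophenyl, 4-iodophenyl, 4-(trifluoromethoxy)phenyl), whereas 2-(trifluoromethyl)phenyl names its group at the 2 position. In this assay this exchange gives a number 0.3 percentage points lower from compound 3 to compound 4 (within the scatter) and a number 3.9 percentage points lower from compound 1 to compound 4 (within the scatter), so a group named at the 2 position of this ring, and a different group at that, cannot be told apart here from those two 4-substituted rings. Within the data shown here, the one step that passes the scatter is a number 12.8 percentage points lower from compound 2 to compound 4 (beyond the scatter), which repeats the gap seen earlier between the iodo compound and compound 3, although compound 1 lies within the scatter of the iodo compound and of compound 4 alike.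

Nothing given here explains why these numbers sit so close together. On these data alone, it also stays open whether a phenyl ring bearing an amine or a carboxylic acid, or a butyl chain in place of the ring on that nitrogen, would give a number in the same range.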